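This account rests on a few compounds, and the source may have more. Where it says the series, first, only, none or still open, it means among the compounds named here.

In an ADME assay on Vero cells (Chlorocebus sabaeus) for inhibition (a higher number here means that more compound is tolerated, a lower number that less compound is tolerated), compound 1 (`O=C1/C(=C/c2ccc(Cl)cc2)CCC/C1=C\c1ccc(Cl)cc1`) gives 32100 nM, level within the scatter with compound 2 (`O=C1/C(=C/c2ccccc2Cl)CCC/C1=C\c1ccccc1Cl`) at 30600 nM. Going by the values given here, compound 3 (`COc1cccc(/C=C2\CCCCC2=O)c1OC`), the one measured compound carrying methoxy, stands far higher at 720000 nM. Compound 4 (`COc1ccc(/C=C2\CCC/C(=C\c3ccc(Cl)cc3)C2=O)cc1`) departs from compound 1 in a single place, methoxy in place of chloro on an aromatic carbon, para to a large group. Among the compounds with values here, no measured pair isolates this change, and compound 3 differs from compound 1 in more than one place, so compound 3 at 720000 nM supports only a weak expectation of direction. The expected step in this assay is small and upward, estimated as a 1.4-fold higher number from compound 1 to compound 4 (0.15 log units; within the scatter), probably within the scatter. Compound 4 is expected at 45000 nM, with an estimated range of 18000 nM to 120000 nM.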

Compound 4, half-maximal cytotoxic concentration: 401000 nM
Compound 4: the middle estimate sits 8.9-fold (0.95 log units) below what was measured; measured number outside the range, above it.
By their numbers in this assay, from the lowest: compounds 2 and 1 (each within the scatter of the next); then compounds 4 and 3 (each within the scatter of the next).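

In this assay, going by these compounds alone, the 4-chlorophenyl to 4-methoxyphenyl change is the only single-place step, and it is large (a 12-fold higher number from compound 1 to compound 4 (1.10 log units; beyond the scatter)), beyond the scatter. This place, para to a large group, is therefore sensitive to the substituent, with the rest of compound 1 left unchanged. Nothing available accounts for the size of this step. Going by these compounds, whether a hydroxyl group or an amine at this place would give a similar step remains open, as does the effect of replacing the remaining chloro with methoxy.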